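Fluoro for methoxy on the pendant phenyl ring

A few compounds are considered here, and "the series" means these few. Any claim that something is new, unique, unknown or untested is made for them only; others in the source may bear on it.

Measured compounds:
Compound 1 `COc1ccc(-c2cn3ccnc3c(-c3ccc4ncn(C5CCCCC5)c4c3)n2)cc1` gives 95.2% in a functional assay on PC-3 cells (Homo sapiens) for inhibition, read by sulforhodamine B assay, with a stated time of 48 h, tested at 10 uM; on this read-out higher numbers stand for more inhibition at the one concentration tested (going by the name of the read-out) and lower numbers for less inhibition.
Compound 2 `Fc1ccc(-c2cn3ccnc3c(-c3ccc4ncn(C5CCCCC5)c4c3)n2)cc1` gives 53.6% in this assay.
Compound 3 `COc1ccccc1-c1cn2ccnc2c(-c2ccc3ncn(C4CCCCC4)c3c2)n1` gives 43.1% in this assay.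

Compound 4 `Fc1ccccc1-c1cn2ccnc2c(-c2ccc3ncn(C4CCCCC4)c3c2)n1` is not yet measured. The three measured compounds share one core and differ only in the pendant phenyl ring. Between compound 1 and compound 2 the difference is fluoro in place of methoxy on an aromatic carbon, and that step reads a number 41.6 percentage points lower from compound 1 to compound 2 (beyond the scatter). Between compound 1 and compound 3 the difference is 2-methoxyphenyl in place of 4-methoxyphenyl on an aromatic carbon, with the step of a number 52.1 percentage points lower from compound 1 to compound 3 (beyond the scatter). Compound 2 and compound 3 are closer, the step being a number 10.5 percentage points lower from compound 2 to compound 3 (beyond the scatter), which leaves compound 3 the lowest of the three.

Compound 4 arises from compound 3 by fluoro in place of methoxy on an aromatic carbon. For the measured compounds named here, this is the same kind of change as the one from compound 1 to compound 2, but not the same: there the fluoro stands para to a large group, here it stands ortho to a large group. The earlier step was large and downward. Compound 3 already starts low, and the read-out cannot fall far below no inhibition, so the step from compound 3 to compound 4 is expected to be smaller than the earlier one, estimated at a number 15.1 percentage points lower from compound 3 to compound 4 (beyond the scatter). Compound 4 is therefore expected to give about 28% in this assay, with a range from 5% to 55%.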

Compound 4, a percentage reported as inhibition, at one concentration (the size of the read-out at that concentration, not a potency): 32.6%
For compound 4 the middle estimate is 4.6 percentage points below the measured one, within the range that was stated.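

Fluoro in place of methoxy gives a lower number in this assay in both pairs, but the size of the step does not carry over from one core to the other: the same change on two cores in this assay, a number 41.6 percentage points lower (beyond the scatter) from compound 1 to compound 2 and a number 10.5 percentage points lower (beyond the scatter) from compound 3 to compound 4, 31.1 percentage points apart, beyond the scatter of two such steps With the fluoro ortho to a large group the step reads a number 10.5 percentage points lower from compound 3 to compound 4 (beyond the scatter), so in this series only the direction of the change carried across these two pairs, not its size, and two pairs do not show why the sizes differ or what a further core would give. The other new steps read a number 21 percentage points lower from compound 2 to compound 4 (beyond the scatter) and a number 62.6 percentage points lower from compound 1 to compound 4 (beyond the scatter), which leaves compound 1 the highest of the four, while each number remains a single reading at one concentration and says nothing about potency.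

The compounds shown leave open whether the 4-methoxyphenyl result is particular to methoxy, since only methoxy and fluoro appear on the pendant phenyl ring, and an ethoxy group, a chlorine, an amine or a carboxylic acid in their place could read quite differently. They also leave open how the change behaves with anything other than cyclohexyl on the shared core, such as a shorter open chain or a piperidine.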